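From Methyl to Furan-2-yl: Compound 2 and Compound 3

The source may report more compounds than this note shows. Statements on the series, on what has been measured and on what is new or still open speak of the compounds shown alone.

In a functional assay on SK-BR-3 cells (Homo sapiens) for cytotoxicity, read by MTT assay, with a stated time of 72 h (on this read-out higher numbers stand for an effect only at larger amounts of compound and lower numbers for an effect already at smaller amounts), compound 1 `COc1cccc(Nc2cc(-c3ccccc3)oc(=O)c2)c1` gives 0.74 uM. Compound 2 `COc1ccc(Nc2cc(C)oc(=O)c2)cc1` gives > 30 uM, which is a limit of the assay and not a number. Its standing is therefore known only as that limit. Compound 3 `COc1ccc(Nc2cc(-c3ccco3)oc(=O)c2)cc1` has furan-2-yl in place of the methyl of compound 2, on an aromatic carbon next to the ring oxygen: furan-2-yl in place of methyl on an aromatic carbon. Going by the values given here, no step between measured compounds is available, so the expectation rests on this structural change and on the value of compound 1, 0.74 uM, the only number so far. The expected step in this assay is an at least 6.0-fold lower number from compound 2 to compound 3 (0.77 log units; beyond the scatter), a move towards lower numbers that is estimated to lie beyond the scatter. For compound 3 the estimated value is 5 uM, with an expected range of 1.2 uM to 22 uM.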

Compound 3, concentration for half-maximal effect: 1.76 uM
Compound 3: middle estimate off by 2.8-fold (0.45 log units), on the high side, and the stated range covers the measured number.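

The step shows that this place on the shared core is not indifferent to what it carries. In this assay, going by these compounds alone, furan-2-yl in place of methyl on the aromatic carbon next to the ring oxygen gives an at least 17-fold lower number from compound 2 to compound 3 (1.23 log units; beyond the scatter), the only change at this place that can be read so far. Its true size stays unknown because compound 2 stands only at a limit of the assay, not at a number: the limit of > 30 uM in this assay, at which 1 of the 3 values shown sits.

As far as these compounds go, whether the effect comes from the five-membered aromatic ring as such or from its oxygen stays open, since compound 1 differs from compound 3 in more than one place. The compounds shown also do not tell how an amine, a carboxylic acid or a longer alkyl chain would behave at this carbon.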